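Hydroxy to Sulfanyl on a Shared Core: Expected Limit

The source may report more compounds than this note shows. Statements on the series, on what has been measured and on what is new or still open speak of the compounds shown alone.

In a functional assay for inhibition, with Homo sapiens as the target (on this read-out lower numbers stand for stronger inhibition and higher numbers for weaker inhibition), compound 2, `CCc1nc(C)c2cnnc(O)n12`, gives > 48000 nM, which is a limit of the assay rather than a number. Compound 1, `Cc1ncn2c(S)nncc12`, gives > 48000 nM in this assay, also a limit. Both sit at the same point, as shown by the limit of > 48000 nM in this assay, at which 2 of the 2 values shown sit, so nothing shown separates them. Compound 3, `CCc1nc(C)c2cnnc(S)n12`, has not yet been measured in this assay. It differs from compound 2 by sulfanyl in place of hydroxy on an aromatic carbon. No measured step is shown, so no size for this exchange can be drawn from the data; compound 1 carries a sulfanyl group and also sits at the limit. The expectation is no change beyond the scatter, with a limit again the most likely outcome. Compound 3 is therefore expected to give about 60000 nM in this assay, within a range from 20000 nM to 200000 nM. That estimate amounts to an expected step that the limit leaves unreadable from compound 2 to compound 3, within the scatter.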

Compound 3, half-maximal inhibitory concentration: > 48000 nM
Compound 3: a limit, no number; the forecaster's own chance of this, stated with the estimate: 85%; the middle value does not contradict the limit.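

No step can be read from compound 3 to compound 1 or compound 2 in this assay because each value is only a limit of the assay: the limit of > 48000 nM in this assay, at which 3 of the 3 values shown sit. The compounds shown leave open whether sulfanyl in place of hydroxy on an aromatic carbon, or ethyl in place of hydrogen on an aromatic carbon, changes inhibition at all.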